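Bromo in Place of Methoxy on an Aryl Urea

The source may report more compounds than this note shows. Statements on the series, on what has been measured and on what is new or still open speak of the compounds shown alone.

Compound 1, `CC(C)c1ccccc1NC(=O)N[C@H](C)c1ccccc1`, gives 17% in an ADME assay on the whole organism with Oryza sativa as the target, tested at 10 uM; a lower number here means a stronger effect, a higher number a weaker effect of the compound at the concentration tested.
Compound 2, `COc1ccccc1NC(=O)N[C@H](C)c1ccccc1`, gives 96% in this assay.

Among the measured compounds shown here, of the two numbers measured, compound 2 stands highest in this assay, with compound 1 as its only neighbour, a number 79 percentage points higher from compound 1 to compound 2 (beyond the scatter). That single step is the whole of what has been measured, and it shows that the group on this aromatic carbon can move the read-out across almost the full scale.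

Compound 3, `C[C@@H](NC(=O)Nc1ccccc1Br)c1ccccc1`, is not yet measured. It differs from compound 2 in one place: bromo in place of methoxy on an aromatic carbon. For the measured compounds named here, no measured step replaces methoxy with bromo, so the step from compound 1 to compound 2 bears on it only by sharing the position, and its size says that a large move is possible in either direction. The account therefore expects compound 3 to fall somewhere between the two measured values, with an expected step of a number 36 percentage points lower from compound 2 to compound 3 (beyond the scatter) downward from compound 2. The estimate for compound 3 in this assay is 60%, expected within 20% to 98%.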

Compound 3, a percentage reported as activity, at one concentration (the size of the read-out at that concentration, not a potency): 94%
Beside the measured number, compound 3's estimate is 34 percentage points below it; the range from low to high includes it.
By their numbers in this assay, from the lowest: compound 1; then compounds 3 and 2 (each within the scatter of the next).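

In this assay, putting bromo in place of methoxy gives a number 2 percentage points lower from compound 2 to compound 3 (within the scatter), so the hydrogen-bond acceptor that methoxy carries can leave this aromatic carbon with no change in the read-out that can be told from scatter. Bromo in place of isopropyl gives a number 77 percentage points higher from compound 1 to compound 3 (beyond the scatter), which makes this the second replacement of isopropyl to produce a large step, and among these three compounds the low number stands with isopropyl alone, with no compound going against that. Nothing available gives a reason why isopropyl stands apart from methoxy and bromo in this assay.

The compounds shown leave open whether the low number belongs to isopropyl alone or would also appear with an ethyl or a tert-butyl group on this aromatic carbon. They also leave open whether an amine or a carboxylic acid at the same place would give a number in the range of compound 2 and compound 3 or one closer to that of compound 1.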